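Swapping a Fluorinated Ring for an Oxadiazole on the Amine

This account rests on a few compounds, and the source may have more. Where it says the series, first, only, none or still open, it means among the compounds named here.

Going by the values given here, compound 3 `CS(=O)(=O)c1cnc(O[C@H]2CC[C@H](OC3CCN(CC4(C(F)(F)F)CCCC4)CC3)CC2)cn1` gives 37% in a functional assay on isolated protein for agonist activity at Glucose-dependent insulinotropic receptor (Homo sapiens), read by HTRF and cAMP accumulation (a higher number here means a larger maximal response, a lower number a smaller maximal response), the lowest of the three numbers measured so far. Compound 1 `CC(C)OC(=O)N1CCC(O[C@H]2CC[C@H](Oc3cnc(S(C)(=O)=O)cn3)CC2)CC1` gives 110% and compound 2 `C[C@H](CF)OC(=O)N1CCC(O[C@H]2CC[C@H](Oc3cnc(S(C)(=O)=O)cn3)CC2)CC1` gives 108%; both carry a ring-free group on the amine nitrogen in a ring, and the steps of a number 73 percentage points lower from compound 1 to compound 3 (beyond the scatter) and a number 71 percentage points lower from compound 2 to compound 3 (beyond the scatter) show how much was lost when that group gave way to the fluorinated five-membered ring. Compound 4 `CC(C)c1noc(CN2CCC(O[C@H]3CC[C@H](Oc4cnc(S(C)(=O)=O)cn4)CC3)CC2)n1` differs from compound 3 by a group of 8 heavy atoms (5 carbon, 2 nitrogen, 1 oxygen; one five-membered aromatic ring with 3 hetero atoms) in place of a group of 9 heavy atoms (6 carbon, 3 fluorine; one five-membered non-aromatic ring of carbon only), on a saturated chain carbon bound to an amine nitrogen in a ring. Among the compounds with values here, this change acts at the same part of the molecule as those two large steps, so a sizable rise is expected, although no measured pair contains this oxadiazole. The expected step is a number 38 percentage points higher from compound 3 to compound 4 (beyond the scatter). Compound 4 is therefore estimated at 75%, within a range from 40% to 110%.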

Compound 4, largest response reached (Emax), in percent of the reference or control that the assay uses: 102%
Beside the measured number, compound 4's estimate is 27 percentage points below it, and the stated range covers the measured number.
By their numbers in this assay, from the lowest: compound 3; then compounds 4, 2 and 1 (each within the scatter of the next).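

In this assay, the 3-isopropyl-1,2,4-oxadiazol-5-yl group gives a number 65 percentage points higher from compound 3 to compound 4 (beyond the scatter), so a five-membered ring on this saturated chain carbon need not cost response; only the carbon ring with fluorine had been seen there. The steps of a number 6 percentage points lower from compound 2 to compound 4 (within the scatter) and a number 8 percentage points lower from compound 1 to compound 4 (within the scatter) show that a response of this size does not need the carbonyl group of compound 1 and compound 2. Nothing available explains the difference between the two rings.

Whether the isopropyl group matters remains open, since the compounds shown include no oxadiazole carrying a methyl or cyclopropyl group instead. How a phenyl ring would behave at this place is also unknown.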